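The source may hold more compounds than are shown below. What is called first, only, known or untested is meant among the compounds shown, and "the series" means these compounds.

Measured so far in an ADME assay on microsomes from liver (Mus musculus) for metabolic stability, read by mass spectrometry, with a stated time of 10 min, tested at 0.5 uM; a higher number here means that more of the compound is left, a lower number that less of the compound is left:
- compound 1 `CNc1cc(Nc2cc(C)cc(C)c2)nn2c(C(N)=O)cnc12` gives 6%
- compound 2 `CNc1cc(Nc2cccc3c2OCCO3)nn2c(C(=O)NC3CC3)cnc12` gives 0%
- compound 3 `CNc1cc(Nc2cccc(-c3ccccc3)c2)nn2c(C(N)=O)cnc12` gives 0%

All three numbers lie close to the bottom of the scale. Compound 1 stands within the scatter of both other compounds, so the set shows no order in this assay.

The next compound is compound 4 `CNc1cc(Nc2cc(C)cc(C)c2)nn2c(C(=O)NCC(C)(C)CO)cnc12`, which keeps the core and the aryl amino group of compound 1. The change is 2-(hydroxymethyl)-2-methylpropyl in place of hydrogen on an amide-type nitrogen, so 2-(hydroxymethyl)-2-methylpropyl takes the place of hydrogen on an amide-type nitrogen.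

For the measured compounds named here, no measured pair isolates a change of this kind. Compound 2 also has a substituent on its amide nitrogen and gives 0%, but it differs from compound 1 elsewhere as well, so it offers only weak guidance. With compound 1 at 6%, little room exists below it. The expected step of a number 2 percentage points higher from compound 1 to compound 4 (within the scatter) is therefore small and upward, and it may not exceed the scatter. The estimated value for compound 4 is 8% within an expected range of 0% to 28% in this measurement.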

Compound 4, percent of the compound remaining: 0%
The estimate for compound 4 lay 8 percentage points above the measured number; the measured number falls inside the stated range.
By their numbers in this assay, from the lowest: compounds 2, 3, 4 and 1 (each within the scatter of the next).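

For the compounds shown here, with the core and the aryl amino group held fixed, compound 4 gives the first reading of a change on this amide-type nitrogen in this assay: 2-(hydroxymethyl)-2-methylpropyl in place of hydrogen yields a number 6 percentage points lower from compound 1 to compound 4 (within the scatter) and so cannot be told apart from the unsubstituted carboxamide. Both numbers lie at the bottom of the scale, so this single pair can show neither a gain nor a real loss from this substituent. Nothing available speaks to a cause for this result.

Going by these compounds, it remains open whether a shorter group such as methyl, or a chain ending in an amine or a carboxylic acid, on the same nitrogen would give a number clear of the scatter. On these data alone, whether any change to the aryl amino group would do so also remains open.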